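A few compounds are considered here, and "the series" means these few. Any claim that something is new, unique, unknown or untested is made for them only; others in the source may bear on it.

Working notes on the series. Four analogues share one core. Compound 1 `O=C1/C(=C/c2ccc([N+](=O)[O-])cc2)S/C(=N\c2ccccc2)N1Cc1ccco1` is reported in a toxicity assay on CHO cells (Cricetulus griseus) for cytotoxicity, read by MTT assay, with a stated time of 72 h (a lower number here means a stronger inhibitor, a higher number a weaker inhibitor), as "not determined" (no result reported), no single number. Compound 3 `CC(C)Oc1ccc(/C=C2\S/C(=N\c3ccccc3)N(Cc3ccco3)C2=O)cc1` is likewise reported there as "not determined" (no result reported), again no single number. Within the data shown here, compound 2 `Cc1ccc(/C=C2\S/C(=N\c3ccccc3)N(Cc3ccco3)C2=O)cc1` is the only member of the set with a result there: in this assay compound 2 gives 185000 nM. Compound 3 therefore stands on no number of its own; one further entry, compound 1, likewise has no number, so the set offers a single measured point.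

Compound 4 `COc1ccc(/C=C2\S/C(=N\c3ccccc3)N(Cc3ccco3)C2=O)cc1` is the next analogue to be run in this assay. Against compound 3 it carries the change (methyl in place of isopropyl on an oxygen on an aromatic ring). Among the measured compounds shown here, no step between two measured compounds is available to calibrate this kind of change, so the size of the shift in this assay cannot be read from the data; the expectation is that it stays within the scatter, in neither direction.

With only compound 2 as a reference, compound 4 is expected to give about 180000 nM in this assay, estimated between 60000 nM and 500000 nM, with the real chance that no single number is reported, as for compound 1 and compound 3.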

Compound 4, half-maximal inhibitory concentration: > 250000 nM
Compound 4: a limit, no number; the forecaster's own chance of this, stated with the estimate: 30%; at least 1.3-fold (0.14 log units) between middle value and limit.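

In this assay compound 4 gives > 250000 nM, a limit of the assay and not a number. Methoxy in place of methyl on an aromatic carbon gives an at least 1.3-fold higher number from compound 2 to compound 4 (0.13 log units; that floor lies within the scatter), the first step in the series at this place, and that floor alone does not separate the two compounds. The isopropoxy to methoxy change and the other steps involving compound 1 or compound 3 cannot be read, as neither compound has a single number.

Going by these compounds, how far compound 4 actually lies from compound 2 stays open, since only a floor is available for that gap. Also open, on these data alone, is whether an amine or a carboxylic acid in place of the methoxy group would give a single number in this assay.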